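From compound 1 to compound 3: a cytotoxicity limit

A few compounds are considered here, and "the series" means these few. Any claim that something is new, unique, unknown or untested is made for them only; others in the source may bear on it.

- Compound 1 `NCCCCNC(=O)Nc1nc2ccc(C(=O)c3ccccc3)cc2[nH]1` gives > 30000 nM as a limit
- Compound 2 `O=C(NCCC1CCNCC1)Nc1nc2ccc(C(=O)c3ccccc3)cc2[nH]1` gives > 30000 nM as a limit

In an ADME assay on CRL8155 cells (Homo sapiens) for cytotoxicity, read by resazurin assay, with a stated time of 72 h (on this read-out higher numbers stand for an effect only at larger amounts of compound and lower numbers for an effect already at smaller amounts), compound 1 stands at a limit, > 30000 nM, and not at a number. Going by the values given here, the one measured step is a step that the two limits leave unreadable from compound 1 to compound 2, so it offers no size to carry over. Compound 3 `O=C(CCCC1CCNCC1)Nc1nc2ccc(C(=O)c3ccccc3)cc2[nH]1` carries 3-(piperidin-4-yl)propyl in place of (4-aminobutyl)amino on a carbonyl carbon. Among the compounds with values here, the only guide is the limit of > 30000 nM in this assay, at which 2 of the 2 values shown sit, shared by compound 1 and compound 2, so no step beyond the usual scatter is expected. The expected step is a number no higher from compound 1 to compound 3 (the limit leaves the size open). For compound 3 the estimate is 30000 nM, with an expected range from 12000 nM to 60000 nM.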

Compound 3, half-maximal effective concentration: > 30000 nM
Compound 3 was reported as a limit (the forecaster's own chance of this, stated with the estimate: 75%); the middle value sits exactly at the limit.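

Going by these compounds alone, compound 1, compound 2 and compound 3 all stand at a limit and not at a number, so no step between them can be read in this assay. The compounds shown leave open how their half-maximal effective concentrations compare: the limit of > 30000 nM in this assay, at which 3 of the 3 values shown sit.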